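Expected Maximal Response after Exchanging the Iodophenyl Group

The compounds below may be only part of what the source reports. "The series", "measured", "known", "first", "only" and "open" are said of these compounds alone.

Compound 2, `N[C@@H](COP(=O)(O)OCCCOC(=O)CCc1ccccc1OCc1cccc(Oc2ccc(I)cc2)c1)C(=O)O`, stands lowest of the two compounds measured in an assay on cells for activation of probable G-protein coupled receptor 34 (Mus musculus), with a stated time of 1 h; a higher number here means a larger maximal response, a lower number a smaller maximal response: in this assay compound 2 gives 0.82, whereas compound 1, `N[C@@H](COP(=O)(O)OCCCOC(=O)CCc1ccccc1OCc1cccc(Oc2ccc(Br)cc2)c1)C(=O)O`, gives 0.97. Among the measured compounds shown here, the one measured step, a number 0.15 lower from compound 1 to compound 2 (beyond the scatter), is the step that leads to compound 2, and it leaves compound 2 as the nearest and only reference point.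

Compound 3, `CC(C)(C)c1cccc(Oc2cccc(COc3ccccc3CCC(=O)OCCCOP(=O)(O)OC[C@H](N)C(=O)O)c2)c1`, differs from compound 2 by 3-(tert-butyl)phenyl in place of 4-iodophenyl on an oxygen on an aromatic ring, that is, 4-iodophenoxy gives way to 3-(tert-butyl)phenoxy.

That single measured step bears only loosely on this change: it exchanged one halogen for another, while the step to compound 3 replaces the whole 4-iodophenyl group with 3-(tert-butyl)phenyl. It shows that a change at this ring can move the maximal response modestly, but gives no direction for a group of this kind. The expected step, a number 0.020 lower from compound 2 to compound 3 (within the scatter), is therefore small, with no clear direction beyond the scatter.

Compound 3 is estimated at 0.8 in this assay, within a range from 0.55 to 1.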

Compound 3, intrinsic activity: the largest response reached, as a fraction of the reference agonist's: 0.39
Estimate against measurement, compound 3: 0.41 above; measured number outside the range, below it.
By their numbers in this assay, from the lowest: compound 3; then compound 2; then compound 1.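

In this assay, putting 3-(tert-butyl)phenyl in place of 4-iodophenyl on an oxygen on an aromatic ring gives a number 0.43 lower from compound 2 to compound 3 (beyond the scatter), and putting it in place of 4-bromophenyl gives a number 0.58 lower from compound 1 to compound 3 (beyond the scatter). Both steps are much larger than the halogen exchange, a number 0.15 lower from compound 1 to compound 2 (beyond the scatter), so this position can shift the maximal response far more than that modest step alone showed. The response is not lost altogether, however: compound 3 still gives 0.39, so the 3-(tert-butyl)phenyl group lowers the response in this series without abolishing it.

On these data alone, the names of the two groups differ both in the substituent and in the number that locates it, so these steps cannot say how much of the fall belongs to the tert-butyl group and how much to its place on the ring, and how a plain phenyl or a methoxyphenyl group would behave here remains open. Nothing at hand accounts for the size of the fall in maximal response.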